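Adding a methylpiperazine to a well-tolerated compound

A few compounds are considered here, and "the series" means these few. Any claim that something is new, unique, unknown or untested is made for them only; others in the source may bear on it.

- Compound 1 `N#Cc1c(-c2cccc(Br)c2)nc(SCc2ccccc2)[nH]c1=O`: > 36000 nM (a limit)
- Compound 2 `O=c1[nH]c(SCc2cc([N+](=O)[O-])cc([N+](=O)[O-])c2)nc2cc(Cl)ccc12`: > 64000 nM (a limit)
- Compound 3 `Cc1ccc2nc(SCc3cc([N+](=O)[O-])cc([N+](=O)[O-])c3)[nH]c(=O)c2c1`: > 64000 nM (a limit)

These three results come from an ADME assay on MRC5 cells (Homo sapiens) for cytotoxicity, read by neutral red uptake; a lower number here means that less compound is tolerated, a higher number that more compound is tolerated. Each of them is a limit and not a number, so none of the three compounds has an exact reading yet. Compound 3 stands at the limit of > 64000 nM in this assay, at which 2 of the 3 values shown sit.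

Compound 4 `CN1CCN(c2ccc3nc(SCc4cc([N+](=O)[O-])cc([N+](=O)[O-])c4)[nH]c(=O)c3c2)CC1` has 4-methylpiperazin-1-yl in place of the methyl of compound 3, on an aromatic carbon (4-methylpiperazin-1-yl in place of methyl on an aromatic carbon). Going by the values given here, no two measured compounds differ in only one place, so the data offer no direct guide to the size of this change. In this assay, a modest move towards less compound being tolerated is expected, although a result within the scatter or another limit would be no surprise. The expected change is an at least 1.6-fold lower number from compound 3 to compound 4 (0.20 log units; that floor lies within the scatter). For compound 4 the estimated value is 40000 nM, with an expected range of 12000 nM to 64000 nM.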

Compound 4, half-maximal cytotoxic concentration: 49000 nM
Compound 4: middle estimate off by 1.2-fold (0.09 log units), on the low side; measured number inside the range.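

Compound 4 is the first compound shown with an exact reading in this assay, so 4-methylpiperazin-1-yl on this aromatic carbon gives a number where the methyl of compound 3 gives only a limit. The change brings an at least 1.3-fold lower number from compound 3 to compound 4 (0.11 log units; that floor lies within the scatter) and so does not establish a drop larger than the normal spread of repeat readings. The step is only a floor, because compound 3 has a limit and not an exact value: (the limit of > 64000 nM in this assay, at which 2 of the 4 values shown sit).

Going by these compounds, the full size of the step stays open, since the reading for compound 3 is a limit. Also open, on these data alone, is whether a morpholine ring, a dimethylamino group or a carboxylic acid on the same carbon would give a reading like that of 4-methylpiperazin-1-yl.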